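Spiro-isoxazoline aryl variation on the shared core

This account rests on a few compounds, and the source may have more. Where it says the series, first, only, none or still open, it means among the compounds named here.

Going by the values given here, compound 2 `C[C@H]1CC[C@@H]2[C@@H](OC(=O)[C@]23CC(c2ccc(Cl)cc2)=NO3)[C@]2(C)C(=O)C=C[C@@]12O` gives 51000 nM in a functional assay on SW-620 cells (Homo sapiens) for cytotoxicity, read by sulforhodamine B assay, with a stated time of 48 h (on this read-out lower numbers stand for stronger inhibition and higher numbers for weaker inhibition), the higher of the two numbers known so far, with compound 1 `COc1ccc(C2=NO[C@]3(C2)C(=O)O[C@@H]2[C@H]3CC[C@H](C)[C@]3(O)C=CC(=O)[C@@]23C)cc1` nearest at 41000 nM. Among the compounds with values here, the only measured step, a 1.2-fold higher number from compound 1 to compound 2 (0.09 log units; within the scatter), swaps one aryl substituent for another and stays within the scatter. Compound 3 `C[C@H]1CC[C@@H]2[C@@H](OC(=O)[C@]23CC(c2ccccc2[N+](=O)[O-])=NO3)[C@]2(C)C(=O)C=C[C@@]12O` carries 2-nitrophenyl in place of 4-chlorophenyl on a carbon with a double bond to nitrogen. Within the data shown here, this change again alters only the aryl group on the same carbon of the shared core, so the one step on hand is the sole guide; it suggests such aryl swaps have so far moved the number little. Among the measured compounds shown here, no measured pair shows the effect of a 2-nitrophenyl, so the expectation rests on the weak response seen in the step from compound 1 to compound 2. Compound 3 is therefore expected to show a step of a 1.0-fold lower number from compound 2 to compound 3 (0.01 log units; within the scatter), with no shift beyond the scatter foreseen. The estimate for compound 3 is 50000 nM, within 20000 nM to 120000 nM.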

Compound 3, half-maximal inhibitory concentration: 40000 nM
Compound 3: middle estimate off by 1.3-fold (0.10 log units), on the high side; the range from low to high includes it.
By their numbers in this assay, from the lowest: compounds 3, 1 and 2 (each within the scatter of the next).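

In this assay, 2-nitrophenyl in place of 4-chlorophenyl on the carbon with a double bond to nitrogen gives a 1.3-fold lower number from compound 2 to compound 3 (0.11 log units; within the scatter) and 2-nitrophenyl in place of 4-methoxyphenyl gives a 1.0-fold lower number from compound 1 to compound 3 (0.01 log units; within the scatter) so all three pairs now lie within the scatter. The number at this position has therefore stayed within the scatter with a group of 9 heavy atoms and 2 hydrogen-bond acceptors entering for 4-chlorophenyl, and with the substituent named at the 2 rather than the 4 position of the phenyl. No measured evidence bears on why this position responds so little.

On these data alone, all three groups here are substituted phenyls on the shared core, so whether any group at this place can move the number beyond the scatter remains open. An amine, a carboxylic acid or a longer alkyl chain in place of the aryl group would test this.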